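Dropping one methoxy from compound 1: what to expect

A few compounds are considered here, and "the series" means these few. Any claim that something is new, unique, unknown or untested is made for them only; others in the source may bear on it.

Measured compounds and their values:
- compound 1 `COc1cc(C(=O)NNC(=S)Nc2csc(-c3ccccc3)c2)cc(OC)c1OC` gives 42000 nM
- compound 2 `COc1cc(C(=O)NNC(=S)Nc2csc(-c3ccc(C)cc3)c2)cc(OC)c1OC` gives 42000 nM
- compound 3 `COc1cc(OC)cc(C(=O)NNC(=S)Nc2csc(-c3ccccc3)c2)c1` gives 42000 nM

In a functional assay on Hs 683 cells (Homo sapiens) for inhibition, read by colorimetric assay and MTT assay, with a stated time of 72 h (on this read-out lower numbers stand for stronger inhibition and higher numbers for weaker inhibition), compound 1 stands level with compounds 2 and 3, all three sharing one value at the digits given. Compound 4 `COc1ccc(C(=O)NNC(=S)Nc2csc(-c3ccccc3)c2)cc1OC` has not yet been measured. It departs from compound 1 by hydrogen in place of methoxy on an aromatic carbon, a change counted as hydrogen in place of methoxy on an aromatic carbon and placed on a six-membered aromatic ring of carbon only.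

The closest guide is no change at the digits printed from compound 1 to compound 3 (within the scatter) for the same kind of exchange, although a different methoxy leaves there. The other measured change, methyl in place of hydrogen on an aromatic carbon, gives no change at the digits printed from compound 1 to compound 2 (within the scatter) and sits elsewhere on the molecule, so it bears on the question only loosely. Neither step exceeds the scatter, yet three compounds are a thin base, and the loss of this particular methoxy has not been tested on its own.

No step beyond the scatter is therefore expected in this assay in either direction. The estimated step is no change at the digits printed from compound 1 to compound 4 (within the scatter) on this reading. Expected for compound 4 is 42000 nM within a range of 22000 nM to 75000 nM on the same evidence.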

Compound 4, half-maximal inhibitory concentration: 22000 nM
Estimate against measurement, compound 4: 1.9-fold (0.28 log units) above; the range from low to high includes it.
By their numbers in this assay, from the lowest: compounds 4, 1, 2 and 3 (each within the scatter of the next).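

In this assay, within the data shown here, the methoxy on the aromatic carbon ortho to a methoxy group and meta to a large group can be exchanged for hydrogen with a 1.9-fold lower number from compound 1 to compound 4 (0.28 log units; within the scatter) as the result, so this position, tested here on its own for the first time, gives no step beyond the scatter. With no change at the digits printed from compound 1 to compound 3 (within the scatter) for the loss of a different methoxy, the two single exchanges of methoxy for hydrogen on compound 1 agree in staying within the scatter, and the full set of methoxy groups in compound 1 is thus not shown to be needed for its level in this assay. No measurement shown gives a reason for this result.

The compounds shown leave open whether an amine, a carboxylic acid or a longer chain such as ethoxy at this position would move the number beyond the scatter in either direction. They also leave open what happens when hydrogen replaces the third methoxy, or when two methoxy groups are replaced together on the same ring.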